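Shortening the nitrogen substituent of a benzimidazole-type vitamin D receptor antagonist

This account rests on a few compounds, and the source may have more. Where it says the series, first, only, none or still open, it means among the compounds named here.

Three analogues sharing one core have been measured in an assay on HEK-293T cells for antagonist activity at vitamin D3 receptor (Homo sapiens), read by a luciferase reporter, with a stated time of 24 h; on this read-out higher numbers stand for weaker inhibition and lower numbers for stronger inhibition. Compound 1 `CC(C)Cn1c(-c2ccc(OCc3c(-c4c(Cl)cccc4Cl)noc3C(C)C)cc2)nc2ccc(C(=O)O)cc21` gives 1180 nM in this assay, compound 2 `CC(C)c1onc(-c2c(Cl)cccc2Cl)c1COc1ccc(-c2nc3ccc(C(=O)O)cc3n2C2CCCCCC2)cc1` gives 921 nM, and compound 3 `CC(C)c1onc(-c2c(Cl)cccc2Cl)c1COc1ccc(-c2nc3ccc(C(=O)O)cc3n2CC2CCCCC2)cc1` gives 346 nM, the lowest of the three numbers. Both measured steps leading to it point the same way: a 3.4-fold lower number from compound 1 to compound 3 (0.53 log units; beyond the scatter) and a 2.7-fold lower number from compound 2 to compound 3 (0.43 log units; beyond the scatter), while a 1.3-fold lower number from compound 1 to compound 2 (0.11 log units; within the scatter).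

Compound 4 `CC(C)c1onc(-c2c(Cl)cccc2Cl)c1COc1ccc(-c2nc3ccc(C(=O)O)cc3n2C(C)C)cc1` has not yet been measured. It differs from compound 3 in one place: isopropyl in place of cyclohexylmethyl on an aromatic nitrogen. The change undoes the kind of move that lowered the number from compound 1 to compound 3, since the group entering has no ring and the cyclohexylmethyl leaves. Among the compounds with values here, the steps that bear on this are those into compound 3, both modest and beyond the scatter. A modest step back upward is therefore expected, a 4.3-fold higher number from compound 3 to compound 4 (0.64 log units; beyond the scatter), giving an estimated value for compound 4 of 1500 nM in this assay, with a range from 500 nM to 4500 nM.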

Compound 4, half-maximal inhibitory concentration: 3550 nM
Estimate against measurement, compound 4: 2.4-fold (0.37 log units) below; measured number inside the range.
By their numbers in this assay, from the lowest: compound 3; then compounds 2 and 1 (each within the scatter of the next); then compound 4.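

Isopropyl on the aromatic nitrogen gives the highest number of the four compounds, and all three steps into compound 4 lie beyond the scatter: a 10-fold higher number from compound 3 to compound 4 (1.01 log units; beyond the scatter), a 3.9-fold higher number from compound 2 to compound 4 (0.59 log units; beyond the scatter) and a 3.0-fold higher number from compound 1 to compound 4 (0.48 log units; beyond the scatter). The first of these steps is large and the other two are modest, so this position responds more strongly to the exchange of cyclohexylmethyl for isopropyl than any earlier step had shown. A ring on this nitrogen is also not required for a lower number than that of compound 4, as compound 1, with isobutyl, shows; nothing available accounts for these differences.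

As far as these compounds go, it remains open how a methyl or ethyl group on this nitrogen would compare with isopropyl. From the compounds shown here alone, it is equally open whether benzyl or cyclopentylmethyl would match cyclohexylmethyl, or whether an amine or a hydroxyl group on that ring would be tolerated.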